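Adding a phenyl to the methylhydrazone of compound 2

This account rests on a few compounds, and the source may have more. Where it says the series, first, only, none or still open, it means among the compounds named here.

Compound 2 `CNN=C1CCC(C)n2c1ncc(C(=O)O)c2=O` carries a methylamino group on the hydrazone nitrogen of the shared core. Going by the values given here, in a functional assay on the whole organism with Rattus norvegicus as the target (on this read-out lower numbers stand for an effect already at smaller amounts and higher numbers for an effect only at larger amounts of compound), compound 2 gives 17.5 umol/kg, the highest of the two numbers measured so far. Its nearest neighbour is compound 1 `CC1CCC(=NNc2cccnc2)c2ncc(C(=O)O)c(=O)n21`, which bears pyridin-3-yl in place of methyl on the same amine nitrogen; in this assay compound 1 gives 0.54 umol/kg. Among the compounds with values here, the single measured step, a 32-fold higher number from compound 1 to compound 2 (1.51 log units; beyond the scatter), shows that trading the aryl group for methyl moves the number far beyond the scatter in the weaker direction.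

Compound 3 `CC1CCC(=NN(C)c2ccccc2)c2ncc(C(=O)O)c(=O)n21` keeps the methyl of compound 2 and adds a phenyl on the amine nitrogen, (phenyl in place of hydrogen on an amine nitrogen). Because the step of a 32-fold higher number from compound 1 to compound 2 (1.51 log units; beyond the scatter) was large when an aryl group was lost, restoring an aryl group is expected to move the number back downward, though the nitrogen now carries both substituents rather than the aryl alone, so the full return to compound 1 is not assumed. Compound 3 is therefore estimated at 2.5 umol/kg, with a range of 0.6 umol/kg to 10 umol/kg, which corresponds to an expected step of a 7.0-fold lower number from compound 2 to compound 3 (0.85 log units; beyond the scatter).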

Compound 3, dose for 50% inhibition: 52.4 umol/kg
Compound 3: the middle estimate sits 21-fold (1.32 log units) below what was measured; the whole stated range lies below it.
By their numbers in this assay, from the lowest: compound 1; then compound 2; then compound 3.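

In this assay, phenyl in place of hydrogen on the amine nitrogen did not bring the number down but gave a 3.0-fold higher number from compound 2 to compound 3 (0.48 log units; beyond the scatter), so on this nitrogen an added aromatic ring does not by itself lead back towards the low number of compound 1. The wider step, a 97-fold higher number from compound 1 to compound 3 (1.99 log units; beyond the scatter), shows that methyl(phenyl)amino and (pyridin-3-yl)amino are far from interchangeable on the double-bonded nitrogen, even though each carries an aromatic ring on the amine nitrogen. No measurement at hand offers an explanation for this order of the three numbers.

The step from compound 1 to compound 3 joins two differences, the added methyl on the amine nitrogen and phenyl in place of pyridin-3-yl, and the compounds shown do not separate them. On these data alone, a plain phenylamino group, with hydrogen in place of that methyl, or a methyl(pyridin-3-yl)amino group would each isolate one of the two differences, so the share of each in the gap remains open.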